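A few compounds are considered here, and "the series" means these few. Any claim that something is new, unique, unknown or untested is made for them only; others in the source may bear on it.

Working notes on the series. Going by the values given here, in a toxicity assay on Vero cells (Chlorocebus sabaeus) for cytotoxicity, read by MTT assay (on this read-out lower numbers stand for stronger inhibition and higher numbers for weaker inhibition), compound 1 `COC(=O)NC(=O)c1ccsc1NC(=O)c1ccc(S(=O)(=O)N2CCC(C)CC2)cc1` gives 9.13 ug/mL and is so far the only compound with a number. Compound 2 `COC(=O)NC(=O)c1ccsc1NC(=O)c1ccc(S(=O)(=O)N2CCC(c3ccccc3)CC2)cc1` carries the same core, but its entry is "nd" (no result reported) and it therefore has no position on the scale. Among the compounds with values here, no step can be read from it, and no measured pair yet shows how a change on the sulfonyl sulfur moves the read-out.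

Compound 3 `COC(=O)NC(=O)c1ccsc1NC(=O)c1ccc(S(=O)(=O)NC2CCOCC2)cc1` is the next to be read. The structural change is (oxan-4-yl)amino in place of 4-phenylpiperidin-1-yl on a sulfonyl sulfur and it places (oxan-4-yl)amino in place of 4-phenylpiperidin-1-yl on a sulfonyl sulfur.

Within the data shown here, with compound 2 lacking a number, the only anchor is compound 1 at 9.13 ug/mL and any expectation rests on that single value. In this assay a moderate step from that anchor is expected, tentatively toward higher numbers and so weaker inhibition, though a result within the usual scatter of it would not be surprising. Compound 3 is estimated at 18 ug/mL with an expected range from 6 ug/mL to 60 ug/mL for the coming measurement.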

Compound 3, half-maximal inhibitory concentration: 35.7 ug/mL
For compound 3 the middle estimate is 2.0-fold (0.30 log units) below the measured one, within the range that was stated.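

In this assay the series now has its first readable step at this position: exchanging 4-methylpiperidin-1-yl on a sulfonyl sulfur for (oxan-4-yl)amino gives a 3.9-fold higher number from compound 1 to compound 3 (0.59 log units; beyond the scatter) and thus shows that the group held there can move the read-out beyond the scatter. The step from compound 2 cannot be read, so this single pair carries all that is known about the position, and 4-phenylpiperidin-1-yl has no place on the scale. Nothing at hand bears on why the number rises with this change.

The step from compound 1 to compound 3 exchanges the whole group at once, so it leaves open whether the higher number in this assay follows the ring oxygen, the amino hydrogen or the loss of the methyl group. Cyclohexylamino and morpholin-4-yl on the same sulfonyl sulfur would each separate part of this, as the first keeps the amino link without the ring oxygen and the second keeps the ring oxygen without the amino hydrogen.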